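The source may hold more compounds than are shown below. What is called first, only, known or untested is meant among the compounds shown, and "the series" means these compounds.

Compound 1 `c1ccc(-c2ccc3oc(NC4CCCCC4)nc3c2)cc1`, compound 2 `Cn1ccc2cc(-c3ccc4oc(Nc5ccc(F)cc5)nc4c3)ccc21`, compound 3 `Cn1ccc2cc(-c3ccc4oc(N5CCc6ccccc6C5)nc4c3)ccc21`.

In an assay on HEK293 cells for inhibition of Fatty-acid amide hydrolase 1 (Homo sapiens), read by fluorescence (a higher number here means a weaker inhibitor, a lower number a stronger inhibitor), compound 1 gives only a limit, > 1000 nM. Compound 2 gives 99 nM and compound 3 gives 55 nM; the two values lie within the scatter of each other, so compound 2 holds the higher of the two numbers without any order being read into it. Compound 4 `Cn1ccc2cc(-c3ccc4oc(N5Cc6ccncc6C5)nc4c3)ccc21` differs from compound 2 by a group of 9 heavy atoms (7 carbon, 2 nitrogen; one five-membered non-aromatic ring with 1 hetero atom, one six-membered aromatic ring with 1 hetero atom) in place of a group of 8 heavy atoms (6 carbon, 1 nitrogen, 1 fluorine; one six-membered aromatic ring of carbon only), on an aromatic carbon. Since compound 3 with a different group at this same place gives 55 nM, close to compound 2, the step from compound 2 to compound 4 in this assay is expected to remain within the scatter, with no clear direction. For compound 4 the estimate is 80 nM, within 25 nM to 300 nM, meaning an expected 1.2-fold lower number from compound 2 to compound 4 (0.09 log units; within the scatter).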

Compound 4, half-maximal inhibitory concentration: 121 nM
Beside the measured number, compound 4's estimate is 1.5-fold (0.18 log units) below it, within the range that was stated.
By their numbers in this assay, from the lowest: compounds 3, 2 and 4 (each within the scatter of the next, the first and the last beyond it). At a limit, above all of these: compound 1.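

In this assay, the group with a five-membered non-aromatic ring and a six-membered aromatic ring with 1 hetero atom replaces (4-fluorophenyl)amino, giving a 1.2-fold higher number from compound 2 to compound 4 (0.09 log units; within the scatter). This place, on the aromatic carbon next to the ring nitrogen and next to the ring oxygen, therefore accepts the loss of the hydrogen-bond donor with no change beyond the scatter.

Going by these compounds, whether an open-chain dimethylamino group or a morpholine would fare the same here stays open. Compound 1 differs from the others in more than one place and gives only a limit, so no step can be read from it: the limit of > 1000 nM in this assay, at which 1 of the 4 values shown sits.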